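Chalcone-type lactam amides: from fluoro to tert-butyl

The source may hold more compounds than are shown below. What is called first, only, known or untested is meant among the compounds shown, and "the series" means these compounds.

Of the compounds shown here, two of one shared core have been measured. Compound 1 `COc1ccccc1/C=C/C(=O)c1ccc(OCC(=O)N[C@H]2CCOC2=O)cc1` carries a 2-methoxyphenyl at the end of its double-bonded chain; in a functional assay on PC-3 cells (Homo sapiens) for antiproliferative activity, read by MTT assay, with a stated time of 72 h (on this read-out lower numbers stand for stronger inhibition and higher numbers for weaker inhibition), compound 1 gives 7240 nM. Compound 2 `O=C(COc1ccc(C(=O)/C=C/c2ccc(F)cc2)cc1)N[C@H]1CCOC1=O` has a 4-fluorophenyl there instead, and in this assay compound 2 gives 15600 nM. Among the measured compounds shown here, that swap is the only measured step, and it reads a 2.2-fold higher number from compound 1 to compound 2 (0.33 log units; beyond the scatter). Compound 2 therefore stands at the higher of the two numbers shown, with compound 1 the only neighbour.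

Compound 3 `CC(C)(C)c1ccc(/C=C/C(=O)c2ccc(OCC(=O)N[C@H]3CCOC3=O)cc2)cc1` keeps everything but the substituent on that outer ring: tert-butyl in place of fluoro on an aromatic carbon. For the measured compounds named here, no measured step concerns a tert-butyl group, and the one step that touches this ring, from compound 1 to compound 2, only shows that changing the group on it moves the number modestly. The expectation for compound 3 is therefore a small step in either direction, a 1.6-fold lower number from compound 2 to compound 3 (0.19 log units; within the scatter), with wide uncertainty. On that basis compound 3 is estimated at 10000 nM, within a range from 3000 nM to 40000 nM.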

Compound 3, half-maximal inhibitory concentration: 10600 nM
For compound 3 the middle estimate is 1.1-fold (0.03 log units) below the measured one, and the stated range covers the measured number.
By their numbers in this assay, from the lowest: compounds 1, 3 and 2 (each within the scatter of the next, the first and the last beyond it).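

Fluoro and tert-butyl differ clearly in size, with 1 heavy atom against 4 carbons, yet at this aromatic carbon, para to a large group, the exchange gives a 1.5-fold lower number from compound 2 to compound 3 (0.17 log units; within the scatter) in this assay, so this larger group does not separate the two compounds. The comparison with the methoxy-bearing compound gives a 1.5-fold higher number from compound 1 to compound 3 (0.17 log units; within the scatter), which means that compound 3 lies within the scatter of both earlier compounds, although those two lie beyond the scatter of each other; the three numbers therefore form a narrow band in which compound 3 cannot be ranked against either neighbour, and the outer ring has so far shown only small steps, whether the group is small or bulky. Nothing measured here gives a reason for these numbers.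

Going by these compounds, whether this flat picture holds for groups of another kind remains open, since an amine or a carboxylic acid on the same ring could still give a number beyond the scatter of these three. The compounds shown also leave open how much the number depends on the rest of the shared core, for example on a longer chain in place of the link to the lactone-bearing amide.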